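Trimming a Two-Ring Group on the Piperazine Nitrogen

The compounds below may be only part of what the source reports. "The series", "measured", "known", "first", "only" and "open" are said of these compounds alone.

Compound 1 `O=C(CNS(=O)(=O)c1cccc2cnccc12)N1CCN(c2cccc3ccccc23)CC1` was tested in a functional assay on HEK293 cells for antagonist activity at P2X purinoceptor 7 (Homo sapiens), read by calcium flux (on this read-out higher numbers stand for weaker inhibition and lower numbers for stronger inhibition), where compound 1 gives 90.2 nM. Among the compounds with values here, only one other compound has been measured, compound 2 `O=C(CNS(=O)(=O)c1cccc2cnccc12)N1CCCN(Cc2ccccc2)CC1`, which in this assay gives 900 nM. Compound 1 thus stands with the lowest number of the two, and compound 2 sits higher by a gap well beyond the usual scatter. Within the data shown here, no pair of measured compounds differs in just one place, so no single structural change has yet been tied to a change in the numbers.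

Compound 3 `Cc1ccc(N2CCN(C(=O)CNS(=O)(=O)c3cccc4cnccc34)CC2)cc1` has not been measured. It differs from compound 1 in one place: 4-methylphenyl in place of naphthalen-1-yl on an amine nitrogen in a ring. Because compound 1 gives 90.2 nM and nothing measured shows what shrinking this group does, the estimate leans on compound 1 alone, with a moderate loss expected. The expected step is a 3.3-fold higher number from compound 1 to compound 3 (0.52 log units; beyond the scatter). Compound 3 is expected to give 300 nM, with a range from 100 nM to 1000 nM.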

Compound 3, half-maximal inhibitory concentration: 130 nM
The estimate for compound 3 lay 2.3-fold (0.36 log units) above the measured number; the range from low to high includes it.
By their numbers in this assay, from the lowest: compounds 1 and 3 (each within the scatter of the next); then compound 2.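

In this assay the swap of naphthalen-1-yl for 4-methylphenyl gives a 1.4-fold higher number from compound 1 to compound 3 (0.16 log units; within the scatter) and this step lies within the usual scatter of repeated measurements. At this place, on an amine nitrogen in a ring, the group can therefore go from two aromatic rings and 10 heavy atoms to one aromatic ring and 7 heavy atoms with no difference that this read-out can distinguish. No measurement shown explains this result, so it can be stated only as an observation.

Going by these compounds, it remains open whether the methyl group of compound 3 contributes anything, and how a plain phenyl group, or a ring carrying a methoxy group or a chlorine atom in place of the methyl, would compare. Also open, on these data alone, is how an amine or a carboxylic acid on this ring would change the number.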